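The compounds below may be only part of what the source reports. "The series", "measured", "known", "first", "only" and "open" are said of these compounds alone.

Measured so far in an assay on A10 cells for antagonist activity at Endothelin-1 receptor (Rattus norvegicus); on this read-out higher numbers stand for weaker inhibition and lower numbers for stronger inhibition:
compound 1, `Cc1ccccc1C(Oc1cc(OCc2ccccc2)ccc1C#N)C(=O)O`: 49 nM
compound 2, `N#Cc1ccc(OCc2ccncc2)cc1OC(C(=O)O)c1ccccc1Cl`: 6 nM

Compound 1 stands highest of the two numbers; compound 2 sits well below it, beyond the usual scatter. Going by the values given here, the two structures differ in more than one place, so no single step between them is drawn; the pair shows only that the lower number belongs to compound 2.

Compound 3, `Cc1ccccc1C(Oc1cc(OCc2ccnc(F)c2)ccc1C#N)C(=O)O`, is not yet measured. It differs from compound 1 by 2-fluoropyridin-4-yl in place of phenyl on a saturated chain carbon bound to an oxygen on an aromatic ring. Among the compounds with values here, no measured pair isolates this change, so the size of the step is uncertain; the step from compound 1 to compound 3 is nevertheless expected to run toward a lower number, of moderate size, a 2.5-fold lower number from compound 1 to compound 3 (0.39 log units; beyond the scatter). That expectation rests on compound 2, which resembles compound 3 more closely at that place than compound 1 does. In this assay compound 2 gives 6 nM. Compound 3 is therefore estimated at 20 nM, with a range from 6 nM to 60 nM.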

Compound 3, half-maximal inhibitory concentration: 23 nM
Compound 3: the middle estimate sits 1.2-fold (0.06 log units) below what was measured; measured number inside the range.
By their numbers in this assay, from the lowest: compound 2; then compound 3; then compound 1.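

Going by these compounds alone, this is the first step that isolates one place: in this assay, 2-fluoropyridin-4-yl in place of phenyl on the core of compound 1 gives a 2.1-fold lower number from compound 1 to compound 3 (0.33 log units; beyond the scatter). The step is modest, but it shows that the read-out responds to the ring at this position and that a six-membered aromatic ring carrying a hetero atom and a fluorine is accepted there without loss of inhibition. Within the data shown here, nothing measured so far accounts for the size or direction of this step.

The ring nitrogen and the fluorine enter together, so this step does not separate their shares. Also open, from the compounds shown here alone, is how the read-out responds to an amine or a methoxy group in place of that fluorine, and to a pyrimidin-4-yl ring in place of the 2-fluoropyridin-4-yl.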